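The source may hold more compounds than are shown below. What is called first, only, known or untested is meant among the compounds shown, and "the series" means these compounds.

Measured in an ADME assay on RAW264.7 cells (Mus musculus) for cytotoxicity, read by MTT assay, with a stated time of 24 h; on this read-out higher numbers stand for weaker inhibition and lower numbers for stronger inhibition:
- Compound 1 `O=C(S[C@]12CC[C@H](O)[C@H]1C(=O)NC2=O)c1ccccc1Cl`: 717000 nM
- Compound 2 `O=C(S[C@@]12CC[C@H](O)[C@@H]1C(=O)NC2=O)c1ccccc1`: 479000 nM

These two measurements are all the data available in this assay. Compound 2, at 479000 nM, lies within the usual scatter of compound 1, at 717000 nM, so the two cannot be told apart on this read-out. The next compound to be considered is compound 3 `O=C(S[C@]12CC[C@H](O)[C@H]1C(=O)NC2=O)c1ccccc1`, which has not yet been measured. Its relation to compound 2 is the two compounds have the same atoms and bonds and differ only in configuration as drawn: 2 of 3 stereo elements differ; a stereocentre at a saturated ring carbon is drawn S in compound 2 and R in compound 3; a stereocentre at a saturated ring carbon is drawn R in compound 2 and S in compound 3. The two compounds have the same atoms and bonds and differ only in configuration as drawn.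

Within the data shown here, no pair of measured compounds shows what such a difference does in this assay, so the data offer no direct precedent. With nothing to indicate a direction, no step beyond the scatter is expected, and this expectation rests only on the closeness of compound 2 at 479000 nM and compound 1 at 717000 nM. The expected change is a 1.1-fold higher number from compound 2 to compound 3 (0.06 log units; within the scatter), an estimate that stays within the scatter. For compound 3 the estimated value is 550000 nM, with an expected range from 240000 nM to 1200000 nM.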

Compound 3, half-maximal inhibitory concentration: 17100000 nM
Estimate against measurement, compound 3: 31-fold (1.49 log units) below, outside the stated range (above it).
By their numbers in this assay, from the lowest: compounds 2 and 1 (each within the scatter of the next); then compound 3.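

In this assay, configuration alone proves to be decisive, with a 36-fold higher number from compound 2 to compound 3 (1.55 log units; beyond the scatter), and this step can be assigned to configuration because nothing else separates the pair: the fact that compounds 2 and 3 differ only in the configuration as drawn

Within the configuration drawn for compound 3, the aromatic substituent also matters: hydrogen in place of chloro on an aromatic carbon gives a 24-fold higher number from compound 1 to compound 3 (1.38 log units; beyond the scatter). Both steps are beyond the scatter and both point towards weaker inhibition, so compound 3 stands apart as the weakest of the three, while compounds 1 and 2 remain within the scatter of each other.

The compounds shown leave open which of the two stereocentres carries the step, as both change together, and whether chloro has the same effect in the configuration drawn for compound 2. They also leave open how a methoxy group or an amine on the aromatic ring would read in this assay.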